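Swapping the Pyrrolidine for a Pyridinylpiperazine

This account rests on a few compounds, and the source may have more. Where it says the series, first, only, none or still open, it means among the compounds named here.

Of the compounds shown here, three share one core and have been tested in a functional assay on MDA-MB-231 cells (Homo sapiens) for inhibition, with a stated time of 72 h; on this read-out lower numbers stand for stronger inhibition and higher numbers for weaker inhibition. Compound 1 `O=C(Nc1ccc(Cl)cc1)Nc1nc(Sc2c[nH]c3ccccc23)cc(N2CCCC2)n1` gives 5850 nM. Compound 2 `O=C(Nc1ccccc1)Nc1nc(Sc2c[nH]c3ccccc23)cc(N2CCCC2)n1` gives 7890 nM, and compound 3 `Cc1cc(Cl)ccc1NC(=O)Nc1nc(Sc2c[nH]c3ccccc23)cc(N2CCCC2)n1` gives 9440 nM. Compound 2 thus holds the second highest of the three numbers, yet all three sit close together: a 1.3-fold higher number from compound 1 to compound 2 (0.13 log units; within the scatter), a 1.6-fold higher number from compound 1 to compound 3 (0.21 log units; within the scatter), and a 1.2-fold higher number from compound 2 to compound 3 (0.08 log units; within the scatter). None of these steps shows a real difference.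

Compound 4 `O=C(Nc1ccccc1)Nc1nc(Sc2c[nH]c3ccccc23)cc(N2CCN(c3ccccn3)CC2)n1` keeps everything in compound 2 except one change: 4-(pyridin-2-yl)piperazin-1-yl in place of pyrrolidin-1-yl on an aromatic carbon. The measured steps all concern the ring on the urea side and leave the pyrrolidin-1-yl untouched, so none of them bears directly on this change; they show only that small edits to this series have moved the numbers little. Within the data shown here, with no step to lean on, the expectation is a change no larger than the scatter in this assay, in either direction, and the uncertainty is wide. Compound 4 is therefore expected to give about 7900 nM, within a range from 2500 nM to 25000 nM. That estimate means a step of a 1.0-fold higher number from compound 2 to compound 4 (0.00 log units; within the scatter) is expected.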

Compound 4, half-maximal inhibitory concentration: 19500 nM
For compound 4 the middle estimate is 2.5-fold (0.39 log units) below the measured one, and the stated range covers the measured number.
By their numbers in this assay, from the lowest: compounds 1, 2 and 3 (each within the scatter of the next); then compound 4.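

Among these compounds, this position on the shared core is the first place where a single change moves the number beyond the scatter: in this assay, the swap gives a 2.5-fold higher number from compound 2 to compound 4 (0.39 log units; beyond the scatter). The urea-side edits had left the numbers close together, whereas this change at the carbon next to the ring nitrogen shifts the result towards weaker inhibition, though only modestly. The position also tolerates a much larger group, with 4-(pyridin-2-yl)piperazin-1-yl bringing 12 heavy atoms where pyrrolidin-1-yl had 5, and inhibition is still measurable.

The compounds shown leave open whether the step follows the piperazine ring or the pyridin-2-yl group on it, which a 4-methylpiperazin-1-yl or morpholin-4-yl group here could help separate. Nothing measured here explains the step.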